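The source may report more compounds than this note shows. Statements on the series, on what has been measured and on what is new or still open speak of the compounds shown alone.

Measured compounds:
- compound 1, `CC[C@@H](Nc1c(C#N)c(-c2ccc(-c3cccnc3C)cc2)nc2cnccc12)C(N)=O`, a physicochemical assay for lipophilicity, read by HPLC, at pH 7.5; a lower number here means a more polar compound, a higher number a more lipophilic compound: 1.9
- compound 2, `CC(C)(CC(N)=O)c1c(C#N)c(-c2ccc(Br)cc2)nc2cnccc12`, this assay: 2.1
- compound 3, `CC[C@@H](Nc1c(C#N)c(-c2ccc(Br)cc2)nc2cnccc12)C(=O)O`, this assay: 1.6

Compound 1 stands second highest of the three numbers in this assay. Its nearest neighbour is compound 2, whose value lies within the scatter of compound 1; compound 3 also lies within the scatter of compound 1. Among the compounds with values here, the only step between measured compounds is a number 0.50 log units lower from compound 2 to compound 3 (beyond the scatter), and it concerns the side chain on the shared core, not the aryl group.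

Compound 4 is `CC[C@@H](Nc1c(C#N)c(-c2ccc(-c3ccc(F)cc3)cc2)nc2cnccc12)C(N)=O`. It differs from compound 1 as follows: 4-fluorophenyl in place of 2-methylpyridin-3-yl on an aromatic carbon. Within the data shown here, no measured step covers this exchange of one aryl group for another, so the expectation rests on the counted change alone: the group that leaves carries one hydrogen-bond acceptor, the group that enters carries none. On that basis a step upward, beyond the scatter, is expected from compound 1 to compound 4 in this assay, a number 0.90 log units higher from compound 1 to compound 4 (beyond the scatter). The value of compound 4 is therefore estimated at 2.8, within a range from 2.3 to 3.3.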

Compound 4, distribution coefficient: 2.7
The estimate for compound 4 lay 0.10 log units above the measured number; measured number inside the range.
By their numbers in this assay, from the lowest: compounds 3, 1 and 2 (each within the scatter of the next, the first and the last beyond it); then compound 4.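

In this assay, 4-fluorophenyl in place of 2-methylpyridin-3-yl on an aromatic carbon, para to a large group, gives a number 0.80 log units higher from compound 1 to compound 4 (beyond the scatter). Within the data shown here, this is the first measured step at this position, and it shows that the number moves beyond the scatter with the rest of compound 1 unchanged, although both groups count 7 heavy atoms and differ in the ring hetero atom, the methyl, the fluorine and the hydrogen-bond acceptor count. Nothing available accounts for the size of this step.

Among these compounds, the single exchange leaves open how much of the step belongs to the ring nitrogen, the methyl or the fluorine, which a plain phenyl or a 2-methylphenyl at this position would help to separate. Also open, going by these compounds, is whether a step of this size holds with other side chains on the shared core, such as the carboxylic acid of compound 3.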